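The source may hold more compounds than are shown below. What is called first, only, known or untested is meant among the compounds shown, and "the series" means these compounds.

Compound 1 `CC(C)CCn1nc(-c2cccs2)c(O)c(C2=NS(=O)(=O)c3cc(O)ccc3N2)c1=O` is measured in an in vitro ADME assay on microsomes from liver (Homo sapiens) for metabolic stability, tested at 5 uM (a higher number here means that the compound lasts longer, a lower number that the compound disappears faster), and gives 0.0933 h, the lowest of the two numbers recorded so far. Compound 2 `CC(C)CCn1nc(-c2cccs2)c(O)c(C2=NS(=O)(=O)c3cc(OCC(N)=O)ccc3N2)c1=O` gives 0.383 h in this assay. Compound 3 `CC(C)CCn1nc(-c2cccs2)c(O)c(C2=NS(=O)(=O)c3cc(CCC(N)=O)ccc3N2)c1=O` carries the change (2-carbamoylethyl in place of hydroxy on an aromatic carbon). Among the compounds with values here, the one step that bears on this is a 4.1-fold higher number from compound 1 to compound 2 (0.61 log units; beyond the scatter), which also removed the free hydroxy in favour of a group ending in an amide. A step of similar size and direction, a 3.2-fold higher number from compound 1 to compound 3 (0.51 log units; beyond the scatter), is therefore expected in this assay. Compound 3 is estimated at 0.3 h, within a range from 0.12 h to 0.8 h.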

Compound 3, half-life: > 1 h
Compound 3 was reported as a limit (the forecaster's own chance of this, stated with the estimate: 5%); middle value at least 3.3-fold (0.52 log units) away from the limit.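

In this assay, putting 2-carbamoylethyl in place of hydroxy on this aromatic carbon goes further than compound 2 suggested, with an at least 10-fold higher number from compound 1 to compound 3 (1.03 log units; beyond the scatter). Compound 2 and compound 3 both carry a group ending in an amide, so the oxygen link in carbamoylmethoxy versus the all-carbon chain also counts here, with an at least 2.6-fold higher number from compound 2 to compound 3 (0.41 log units; beyond the scatter). The value of compound 3 is a limit, not a number: the limit of > 1 h in this assay, at which 1 of the 3 values shown sits.

Going by these compounds, whether the amide end itself matters remains open. A carboxylic acid or an amine at the end of the chain, or a longer chain, could answer that.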